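Compound 3: swapping the halogen-bearing phenyl group

The source may report more compounds than this note shows. Statements on the series, on what has been measured and on what is new or still open speak of the compounds shown alone.

Measured in a functional assay on MIA PaCa-2 cells (Homo sapiens) for inhibition, read by MTT assay, with a stated time of 48 h, tested at 10 uM; a lower number here means less inhibition of growth, a higher number more inhibition of growth at the concentration tested:
- compound 1 `Cc1oc2c([C@H]3CCN(C)C[C@H]3O)c(O)cc(O)c2c(=O)c1C(O)c1csc([N+](=O)[O-])c1`: 41%
- compound 2 `Cc1oc2c([C@H]3CCN(C)C[C@H]3O)c(O)cc(O)c2c(=O)c1C(O)c1cc(F)cc(F)c1`: 6%

Compound 2, at 6%, has the lower of the two numbers in this assay, and compound 1 stands clearly above it. Compound 3 `Cc1oc2c([C@H]3CCN(C)C[C@H]3O)c(O)cc(O)c2c(=O)c1C(O)c1cccc(Cl)c1Cl` has not yet been measured. It keeps the shared core of compound 2 and changes one group: 2,3-dichlorophenyl in place of 3,5-difluorophenyl on a saturated chain carbon bound to an aromatic carbon and an oxygen on a saturated carbon. In words, 2,3-dichlorophenyl replaces 3,5-difluorophenyl on a saturated chain carbon bound to an aromatic carbon and an oxygen on a saturated carbon.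

Within the data shown here, only one measured step bears on this place: a number 35 percentage points lower from compound 1 to compound 2 (beyond the scatter). That large step shows that a change here can matter, but it replaced 5-nitrothiophen-3-yl, whereas both groups now in play are halogen-bearing phenyl groups. Among the measured compounds shown here, no measured compound carries the 2,3-dichlorophenyl group, so the direction is uncertain. A small upward lean is expected, with a wide margin. The expected change is a number 8 percentage points higher from compound 2 to compound 3 (within the scatter), probably not beyond the scatter. For compound 3 the estimated value is 14%, with an expected range of 2% to 38%.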

Compound 3, percent growth inhibition at one concentration: 2%
For compound 3 the middle estimate is 12 percentage points above the measured one; low and high end bracket the measured number.
By their numbers in this assay, from the lowest: compounds 3 and 2 (each within the scatter of the next); then compound 1.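

In this assay, the step of a number 4 percentage points lower from compound 2 to compound 3 (within the scatter) shows that exchanging 3,5-difluorophenyl for 2,3-dichlorophenyl at this carbon does not separate the two compounds, even though the halogen and its places on the ring both change. The step of a number 39 percentage points lower from compound 1 to compound 3 (beyond the scatter) is large, as is a number 35 percentage points lower from compound 1 to compound 2 (beyond the scatter), so among these three compounds, both halogen-bearing phenyl groups stand clearly apart from 5-nitrothiophen-3-yl, and no compound shown goes against this. No supporting measurement is available to explain why these groups differ in this way.

The compounds shown leave open whether the difference follows the nitro group, the thiophene ring or the two together, which a nitrophenyl group and a thiophene ring without the nitro group could help to separate. They also leave open whether a phenyl ring with neither halogen, or one carrying an amine or a carboxylic acid, would stay with compound 2 and compound 3 or move towards compound 1.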